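Chloro on the shared core: compound 2 to compound 3

The compounds below may be only part of what the source reports. "The series", "measured", "known", "first", "only" and "open" are said of these compounds alone.

In a functional assay on PC-3 cells (Homo sapiens) (on this read-out lower numbers stand for stronger inhibition of growth and higher numbers for weaker inhibition of growth), compound 1 `O=S(=O)(/C=C/c1ccccc1)Cc1ccc(Nc2ncnc3ccccc23)cc1` gives > 100000 nM, which is a limit and not a number. Among the measured compounds shown here, compound 2 `O=S(=O)(/C=C/c1ccc(F)cc1Cl)Cc1ccc(Nc2ncnc3ccccc23)cc1` gives 100000 nM, the only true number so far. For the measured compounds named here, the one measured step, a number no higher from compound 1 to compound 2 (the limit leaves the size open), has no readable size, and it leaves the shared core untouched.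

Compound 3 `O=S(=O)(/C=C/c1ccc(F)cc1Cl)Cc1ccc(Nc2ncnc3cc(Cl)ccc23)cc1` keeps the whole of compound 2 and adds one change, chloro in place of hydrogen on an aromatic carbon. Going by the values given here, no measured step involves this place, so the series offers no direct guide to the size of the change. With compound 2 at 100000 nM, a moderate move toward stronger inhibition in this assay is expected, though this is a weakly supported expectation. A result that is again only a limit remains a real possibility. The expected change is a 2.0-fold lower number from compound 2 to compound 3 (0.30 log units; within the scatter). For compound 3 the estimated value is 50000 nM, with an estimated range of 12000 nM to 100000 nM.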

Compound 3, concentration for 50% growth inhibition: 73000 nM
For compound 3 the middle estimate is 1.5-fold (0.16 log units) below the measured one; low and high end bracket the measured number.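

In this assay, among the compounds shown here, this position gives the first step with a readable size: a 1.4-fold lower number from compound 2 to compound 3 (0.14 log units; within the scatter). Chloro in place of hydrogen on an aromatic carbon of the shared core, on a compound already carrying the 2-chloro-4-fluorophenyl group, thus leaves the read-out within the scatter, and compound 3 gives no sign that this change alters growth inhibition. The reading carries limited weight, as the series stands at the weak end of what the read-out reports: the limit of > 100000 nM in this assay, at which 1 of the 3 values shown sits.

The compounds shown leave open whether chloro at this place would count for more on a compound with a much lower number in this assay. They also leave open what an amine, a methoxy group or a longer chain at this place would do to the read-out, and whether any group here can move it beyond the scatter.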